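The compounds below may be only part of what the source reports. "The series", "measured", "known", "first", "only" and "open" are said of these compounds alone.

Measured in a functional assay on MDA-MB-231 cells (Homo sapiens) for inhibition, read by CCK-8 assay, with a stated time of 48 h; on this read-out higher numbers stand for weaker inhibition of growth and lower numbers for stronger inhibition of growth:
- compound 1 `Cc1ccccc1Nc1nc(Nc2ccc(N3CCN(C)CC3)cn2)ncc1Cl`: 7470 nM
- compound 2 `CN1CCN(c2ccc(Nc3ncc(Cl)c(NCc4ccc(C(F)(F)F)cc4)n3)nc2)CC1`: 19100 nM
- compound 3 `CN1CCN(c2ccc(Nc3ncc(Cl)c(NCc4ccc(F)cc4)n3)nc2)CC1`: > 100000 nM

The entry for compound 3 is a limit of the assay and not a number. The series therefore offers (the limit of > 100000 nM in this assay, at which 1 of the 3 values shown sits), and compound 3 has no exact position among the values.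

The next compound is compound 4 `COc1ccc(CNc2nc(Nc3ccc(N4CCN(C)CC4)cn3)ncc2Cl)cc1`, with methoxy in place of fluoro on an aromatic carbon, para to a large group: methoxy in place of fluoro on an aromatic carbon.

The nearest measured change is at this same place: an at least 5.2-fold higher number from compound 2 to compound 3 (0.71 log units; beyond the scatter). This is fluoro in place of trifluoromethyl, so a change at this place has moved the read-out in this assay by at least a modest amount. The other two steps, a 2.6-fold higher number from compound 1 to compound 2 (0.41 log units; beyond the scatter) and an at least 13-fold higher number from compound 1 to compound 3 (1.12 log units; beyond the scatter), exchange the whole 2-methylphenyl group and bear less directly on this change. Going by the values given here, no methoxy compound has been measured yet.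

With compound 2 at 19100 nM, a measurable number is known for one benzyl compound, so a modest move toward a lower number is expected. Compound 4 may also reach the limit of the assay. The estimated step is an at least 2.2-fold lower number from compound 3 to compound 4 (0.34 log units; beyond the scatter). For compound 4 the estimate is 45000 nM, with an expected range of 15000 nM to 100000 nM.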

Compound 4, concentration for 50% growth inhibition: 14900 nM
For compound 4 the middle estimate is 3.0-fold (0.48 log units) above the measured one, and the stated range ends above it.
By their numbers in this assay, from the lowest: compounds 1, 4 and 2 (each within the scatter of the next, the first and the last beyond it). At a limit, above all of these: compound 3.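

In this assay, this aromatic carbon proves able to carry a group other than trifluoromethyl and still give a measurable number, with methoxy in place of fluoro giving an at least 6.7-fold lower number from compound 3 to compound 4 (0.82 log units; beyond the scatter). Methoxy and trifluoromethyl cannot be told apart at this place, at a 1.3-fold lower number from compound 2 to compound 4 (0.11 log units; within the scatter), and the 4-methoxybenzyl group is likewise not separated from 2-methylphenyl on the nitrogen, at a 2.0-fold higher number from compound 1 to compound 4 (0.30 log units; within the scatter), so among the benzyl compounds shown the fluoro compound alone stands apart. Compound 3 remains a limit of the assay and not a number, so the step from it gives only a bound and its full size cannot be read: the limit of > 100000 nM in this assay, at which 1 of the 4 values shown sits.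

On these data alone, whether a hydrogen, a chloro or a dimethylamino group on this aromatic carbon would fall with methoxy and trifluoromethyl or with fluoro remains open. The three benzyl compounds also give no reason for the separate position of the fluoro compound, and they do not show whether any group at this place can bring the number clearly below that of compound 1.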